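The source may hold more compounds than are shown below. What is called first, only, known or untested is meant among the compounds shown, and "the series" means these compounds.

Measured in a functional assay on RAW264.7 cells (Mus musculus) for inhibition, read by ELISA, with a stated time of 24 h; on this read-out higher numbers stand for weaker inhibition and lower numbers for stronger inhibition:

- compound 1 `O=C(/C=C/c1ccccc1)OC[C@@]1(O)CO[C@@H](O[C@@H]2[C@@H](O)[C@H](OCc3ccccc3)O[C@H](CO)[C@H]2O)[C@@H]1O` gives 39600 nM
- compound 2 `O=C1C[C@@H](c2ccc(O)c(O)c2)Oc2cc(O[C@@H]3O[C@H](CO)[C@@H](O)[C@H](O)[C@H]3O)cc(O)c21` gives 41200 nM
- compound 3 `O=C(/C=C/c1ccccc1)OC[C@H]1O[C@@H](Oc2cc(O)c3c(c2)O[C@H](c2ccc(O)c(O)c2)CC3=O)[C@H](O)[C@@H](O)[C@@H]1O` gives 25100 nM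

Among these three numbers compound 2 stands at the highest, though its distance to compound 1 and to compound 3 is within the scatter of this assay, so no order among them can be claimed. Compound 4 `O=C(/C=C/c1ccccc1)O[C@H]1[C@H](Oc2cc(O)c3c(c2)O[C@H](c2ccc(O)c(O)c2)CC3=O)O[C@H](CO)[C@@H](O)[C@@H]1O` differs from compound 2 by (2-phenylethenyl)carbonyl in place of hydrogen on an oxygen on a saturated carbon. Going by the values given here, the one measured step with the same kind of change is a 1.6-fold lower number from compound 2 to compound 3 (0.22 log units; within the scatter), where the group entered on a different oxygen of the same sugar. On that basis the step from compound 2 to compound 4 is expected to stay within the scatter: a 1.4-fold lower number from compound 2 to compound 4 (0.14 log units; within the scatter). Compound 4 is therefore estimated at 30000 nM, with a range from 12000 nM to 75000 nM.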

Compound 4, half-maximal inhibitory concentration: 15600 nM
Beside the measured number, compound 4's estimate is 1.9-fold (0.28 log units) above it; low and high end bracket the measured number.
By their numbers in this assay, from the lowest: compounds 4, 3, 1 and 2 (each within the scatter of the next, the first and the last beyond it).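

In this assay, going by these compounds alone, (2-phenylethenyl)carbonyl on this oxygen gives the first step here beyond the scatter, though a modest one: a 2.6-fold lower number from compound 2 to compound 4 (0.42 log units; beyond the scatter). On a different oxygen of the same sugar, the same group gave a 1.6-fold lower number from compound 2 to compound 3 (0.22 log units; within the scatter), so the site may matter, yet compound 3 and compound 4 lie within the scatter of each other. Nothing available explains the step. Still open, as far as these compounds go, is whether a smaller acetyl group on this oxygen would also lower the number, or whether an amine or a carboxylic acid on the aromatic ring of the entering group would change the step.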